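This account rests on a few compounds, and the source may have more. Where it says the series, first, only, none or still open, it means among the compounds named here.

Measured compounds:
compound 1, `Fc1cccc(C#Cc2nc3c(s2)CN(C2CCOC2)CC3)c1`, 400 nM
compound 2, `O=C(C1CC1)N1CCc2nc(C#Cc3ccccc3)sc2C1`, 290 nM

In an assay on HEK293 cells for negative allosteric modulation of metabotropic glutamate receptor 5 (Homo sapiens), read by FLIPR, with a stated time of 1 h (a lower number here means a stronger inhibitor, a higher number a weaker inhibitor), compound 2 gives the lower of the two numbers; the nearest is compound 1, whose value in this assay is within the usual scatter of that of compound 2, so the two cannot be placed in order. Compound 3, `CC1CCC(C(=O)N2CCc3nc(C#Cc4ccccc4)sc3C2)CC1`, has not been measured. It differs from compound 2 in one place: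

4-methylcyclohexyl in place of cyclopropyl on a carbonyl carbon

Among the measured compounds shown here, no step between two measured compounds shows how a change on this carbonyl carbon plays out, so the expectation rests on the two values alone, which sit close together. Compound 3 is expected to stay near compound 2, with the step of a 1.2-fold lower number from compound 2 to compound 3 (0.06 log units; within the scatter) estimated to lie within the scatter rather than beyond it in either direction. The estimate for compound 3 in this assay is 250 nM, with a range from 70 nM to 900 nM.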

Compound 3, half-maximal inhibitory concentration: > 10000 nM
Compound 3 was reported as a limit; the forecaster's own chance of this, stated with the estimate: 5%; middle value at least 40-fold (1.60 log units) from the limit.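

On the carbonyl carbon, the two groups do not read alike: in this assay, 4-methylcyclohexyl in place of cyclopropyl gives an at least 34-fold higher number from compound 2 to compound 3 (1.53 log units; beyond the scatter). The earlier compounds shown here offered no step at this position, and this one shows that it responds strongly to this change, which takes the group from 3 heavy atoms to 7 with no hydrogen-bond donor or acceptor in either group. The number for compound 3 is a limit of the assay and not a measured value: the limit of > 10000 nM in this assay, at which 1 of the 3 values shown sits.

Going by these compounds, only these two groups can be compared on this carbonyl carbon, so it remains open whether the larger ring, the methyl on it or both account for the step. The compounds shown also leave open how a plain cyclohexyl, a tert-butyl or a cyclic amine such as piperidin-4-yl would read here.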